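The compounds below may be only part of what the source reports. "The series", "measured", "known", "first", "only" and "open" are said of these compounds alone.

Compound 1 `Cc1nc2c(OCc3ccccc3)cccn2c1N` is the reference point of this small series. Among the measured compounds shown here, in a functional assay on the whole organism with Canis familiaris (Canis lupus familiaris) as the target, at a dose of 2 mg/kg by the oral route (on this read-out lower numbers stand for a weaker effect and higher numbers for a stronger effect at the one dose given), compound 1 gives 50%, the highest of the two numbers measured so far. For the measured compounds named here, its only measured neighbour is compound 2 `Cc1nc2c(OCc3ccccc3F)cccn2c1N`, which in this assay gives 20%. Going by the values given here, the single step between them, a number 30 percentage points lower from compound 1 to compound 2 (beyond the scatter), came from a fluoro in place of hydrogen on an aromatic carbon of the benzyl ring.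

Compound 3 `Cc1nc2c(OCc3ccc(Cl)cc3)cccn2c1N` has not yet been measured. It differs from compound 1 by chloro in place of hydrogen on an aromatic carbon. Among the compounds with values here, the one measured step that bears on this change is the fluoro step, which lowered the read-out by a modest amount; a chloro on the same ring, though at a different place, is the closest guide available, so a drop of similar size or smaller is expected rather than a gain. Compound 3 is therefore estimated to give 35%, within a range from 10% to 60%. The expected step is a number 15 percentage points lower from compound 1 to compound 3 (beyond the scatter).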

Compound 3, a percentage reported as inhibition, in the whole organism at one dose (the size of the read-out at that dose, not a potency): 32%
The estimate for compound 3 lay 3 percentage points above the measured number; measured number inside the range.
By their numbers in this assay, from the lowest: compound 2; then compound 3; then compound 1.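

In this assay, a chloro para to a large group on the six-membered aromatic ring also reduces the effect, giving a number 18 percentage points lower from compound 1 to compound 3 (beyond the scatter). Alongside a number 30 percentage points lower from compound 1 to compound 2 (beyond the scatter), this makes two single halogen changes on this ring, at different places, and both give a lower number, so a drop is not confined to one halogen or one place among the compounds shown. No measurement here explains either drop.

Still open, going by these compounds, is whether a fluoro at this same place would give a similar drop, which would help separate the effect of the halogen from that of its position. It is also unknown whether a non-halogen group here, such as a methoxy group or an amine, would retain the effect of compound 1.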